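Hydroxy on the cinnamoyl ring of the catechol amide series

The source may hold more compounds than are shown below. What is called first, only, known or untested is meant among the compounds shown, and "the series" means these compounds.

Measured compounds and their activity in this assay:
compound 1 `O=C(/C=C/c1ccccc1)N1CCc2c(Cl)c(O)c(O)c(Cl)c2C1` — 41%
compound 2 `O=C(CCCc1ccc(C(F)(F)F)cn1)N1CCc2c(Cl)c(O)c(O)c(Cl)c2C1` — 19%

Working notes. In a functional assay (Homo sapiens), tested at 10 uM (a lower number here means a stronger effect, a higher number a weaker effect of the compound at the concentration tested), compound 1 gives 41%, the highest of the two numbers recorded. The nearest number is that of compound 2, which in this assay gives 19%, a gap beyond the scatter. Compound 2 carries a different amide side chain altogether, so its number says nothing about single changes on the cinnamoyl ring of compound 1.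

Compound 3 `O=C(/C=C/c1ccc(O)cc1)N1CCc2c(Cl)c(O)c(O)c(Cl)c2C1` has not been measured in this assay. Relative to compound 1 the change is hydroxy in place of hydrogen on an aromatic carbon. Among the measured compounds shown here, no measured pair shows this change, so the size of the step is unknown. Without any comparable step, the expectation is a step of a number 6 percentage points lower from compound 1 to compound 3 (within the scatter) toward a somewhat lower number, small and possibly within the scatter. For compound 3 the activity in this assay is therefore estimated at 35%, with a range from 15% to 60%.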

Compound 3, a percentage reported as activity, at one concentration (the size of the read-out at that concentration, not a potency): 32%
For compound 3 the middle estimate is 3 percentage points above the measured one; measured number inside the range.
By their numbers in this assay, from the lowest: compound 2; then compounds 3 and 1 (each within the scatter of the next).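

Among the compounds shown here, this is the first single-place comparison. In this assay, replacing hydrogen with hydroxy on the aromatic ring of the cinnamoyl side chain, the change from phenyl to 4-hydroxyphenyl, gives a number 9 percentage points lower from compound 1 to compound 3 (within the scatter). For the compounds shown here, at this place, para to a large group, a hydroxy group therefore brings no step that can be told apart from the scatter, and compound 1 and compound 3 read as equivalent in this assay. No available evidence accounts for the size of this step.

Going by these compounds, it remains open whether a methoxy group, a fluorine atom, an amine or a carboxylic acid at the same place would give a step beyond the scatter, and whether hydroxy on another carbon of the ring would read the same. On these data alone, compound 2 differs from compound 1 and compound 3 across the whole side chain, so no single change yet connects it to them, and the effect of a saturated chain in place of the double bond of compound 1 also remains open.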